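Removing One Methyl from Compound 1

The compounds below may be only part of what the source reports. "The series", "measured", "known", "first", "only" and "open" are said of these compounds alone.

Measured in a functional assay on U-87MG ATCC cells (Homo sapiens) for cytotoxicity, read by MTT assay, with a stated time of 48 h; on this read-out lower numbers stand for stronger inhibition and higher numbers for weaker inhibition:
Compound 1 `CC(C)=CCC/C(C)=C/CC/C(C)=C/CSc1ccccc1C(=O)N[C@@H](C)C(=O)OC(C)CCOc1no[n+]([O-])c1S(=O)(=O)c1ccccc1`: 20400 nM
Compound 2 `CC(C)=CCC/C(C)=C/CC/C(C)=C/CSc1ccccc1C(=O)NCC(=O)OCCCCOc1no[n+]([O-])c1S(=O)(=O)c1ccccc1`: > 50000 nM (a limit of the assay, not a number)
Compound 3 `CC(C)=CCC/C(C)=C/CC/C(C)=C/CSc1ccccc1C(=O)N1CCC[C@H]1C(=O)OCCOCCOc1no[n+]([O-])c1S(=O)(=O)c1ccccc1`: 12900 nM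

Compound 1, at 20400 nM, lies within the usual scatter of compound 3, so these two numbers are best read as alike. The third result gives no number to compare with them.

Compound 4 `CC(C)=CCC/C(C)=C/CC/C(C)=C/CSc1ccccc1C(=O)NCC(=O)OC(C)CCOc1no[n+]([O-])c1S(=O)(=O)c1ccccc1` has not yet been measured. It differs from compound 1 by hydrogen in place of methyl on a saturated chain carbon bound to an amide-type nitrogen and a carbonyl carbon.

Within the data shown here, no two measured compounds differ in just one place, so the size of this change in this assay cannot be read from the data and remains a judgement. A modest move toward weaker inhibition is expected, and the result may turn out to be only a limit. The expected step of a 1.5-fold higher number from compound 1 to compound 4 (0.17 log units; within the scatter) is an estimate. Compound 4 is estimated at 30000 nM, with an expected range from 13000 nM to 50000 nM.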

Compound 4, half-maximal inhibitory concentration: 15400 nM
Compound 4: the middle estimate sits 1.9-fold (0.29 log units) above what was measured, and the stated range covers the measured number.
By their numbers in this assay, from the lowest: compounds 3, 4 and 1 (each within the scatter of the next). At a limit, above all of these: compound 2.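

In this assay, putting hydrogen in place of methyl on the saturated chain carbon bound to an amide-type nitrogen and a carbonyl carbon gives a 1.3-fold lower number from compound 1 to compound 4 (0.12 log units; within the scatter). Among these compounds, this is the first comparison here between two compounds that differ in just one place, and it shows that losing this methyl leaves a difference no larger than repeat measurements would produce, so the two compounds read as alike. Compound 2 cannot join this comparison, as it gives a limit and not a number: the limit of > 50000 nM in this assay, at which 1 of the 4 values shown sits.

As far as these compounds go, whether a larger group on this carbon, such as a longer chain, an amine or a carboxylic acid, would also leave the result unmoved remains open. A single step also cannot tell whether the same swap would read alike in a compound with a different chain on the ester.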